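The source may hold more compounds than are shown below. What is called first, only, known or untested is meant among the compounds shown, and "the series" means these compounds.

Measured so far in an ADME assay on HEL cells (Homo sapiens) for cytotoxicity, with a stated time of 3 days; a lower number here means that less compound is tolerated, a higher number that more compound is tolerated:
compound 1 `C=Cc1ccc(-c2cc(C)c3ncc(CSCCc4ccccc4)n3c2)cc1` gives 20 ug/mL
compound 2 `Cc1cc(-n2cccc2)cn2c(CSCCc3ccccc3)cnc12` gives >= 4 ug/mL, a limit of this assay rather than a number

Compound 2 stands only at a limit in this assay, (the limit of >= 4 ug/mL in this assay, at which 1 of the 2 values shown sits). The step that the limit leaves unreadable from compound 1 to compound 2 is for that reason not readable in size. Compound 3 `Cc1cc(-n2ccc3ccccc32)cn2c(CSCCc3ccccc3)cnc12` differs from compound 2 by 1H-indol-1-yl in place of 1H-pyrrol-1-yl on an aromatic carbon. Among the measured compounds shown here, no measured step bears readably on this change, so no direction beyond the scatter is expected in this assay. For compound 3 the expected value is 20 ug/mL, within a range from 4 ug/mL to 100 ug/mL. The estimated step that the limit leaves unreadable from compound 2 to compound 3 is expected to be small, with a fair chance that only a limit is reported.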

Compound 3, minimum cytotoxic concentration: > 20 ug/mL
Compound 3: only a limit was reported; the forecaster's own chance of this, stated with the estimate: 40%; the middle value sits exactly at the limit.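

In this assay compound 3 gives > 20 ug/mL, a limit of the assay and not a number. With 1H-indol-1-yl in place of 4-vinylphenyl on this aromatic carbon, the printed result is a number no lower from compound 1 to compound 3 (the limit leaves the size open), so a group with a fused six-membered aromatic ring stands at this position with no drop from compound 1. The step from the 1H-pyrrol-1-yl group of compound 2 cannot be read in size, nor can the earlier one.

Still open, going by these compounds, is where compound 2 and compound 3 truly lie relative to each other. Also open, on these data alone, is how a piperidine amine or a carboxylic acid on this carbon would read.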